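The source may report more compounds than this note shows. Statements on the series, on what has been measured and on what is new or still open speak of the compounds shown alone.

Measured compounds: compound 1 `c1ccc(CNCC[C@@H]2CCC[C@@H](c3ccccc3)C2)cc1` with 1.8 nM; 2.4 nM (2 entries); compound 2 `CN(C)CCC1CCCC(c2ccccc2)C1` with 4.2 nM; compound 3 `NCC[C@H]1CCC[C@@H](c2ccccc2)C1` with 138 nM.

In an assay on membranes from brain for displacement of a labelled ligand from Sigma non-opioid intracellular receptor 1 (Cavia porcellus), read by scintillation counting, with a stated time of 120 min (on this read-out higher numbers stand for weaker inhibition and lower numbers for stronger inhibition), compound 2 gives the lowest of the two single numbers, and its nearest neighbour, compound 3, gives a markedly higher number, a gap beyond the scatter. Compound 1 stands beside them with two entries the several entries of compound 1 in this assay, 1.8 nM; 2.4 nM (2 entries) and no single number. The step from compound 2 to compound 4 `CN(C)CC[C@@H]1CCC[C@H](c2ccccc2)C1` changes no atom or bond: the two compounds have the same atoms and bonds; at least one stereo element is drawn with a configuration in one of them and without one in the other: 2 of 2 stereo elements differ; a stereocentre at a saturated ring carbon is drawn without a configuration in compound 2 and R in compound 4; a stereocentre at a saturated ring carbon is drawn without a configuration in compound 2 and S in compound 4. Drawing the configuration of both ring stereocentres is expected to move the number little, no more than the scatter, in either direction. Compound 4 is therefore estimated at 3.5 nM (range 1.2 nM to 12 nM), a step of a 1.2-fold lower number from compound 2 to compound 4 (0.08 log units; within the scatter) expected from compound 2.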

Compound 4, inhibition constant: 14 nM
The estimate for compound 4 lay 4.0-fold (0.60 log units) below the measured number; the measured number lies above the stated range.
By their numbers in this assay, from the lowest: compound 2; then compound 4; then compound 3.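

In this assay defining both ring stereocentres gives a 3.3-fold higher number from compound 2 to compound 4 (0.52 log units; beyond the scatter) with atoms and bonds unchanged. Among these compounds, this is the first sign that the drawn configuration at these two ring carbons matters here, since the earlier compounds offered no such comparison. The step cannot be read as one configuration set against another, because it rests on this: the fact that one of compounds 2 and 4 is drawn with a defined configuration and the other without, at the place where they differ.

As far as these compounds go, how the opposite configuration of compound 4 would read remains open. So does whether a diethylamino group in place of the dimethylamino group would respond to configuration in the same way.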